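The source may hold more compounds than are shown below. What is called first, only, known or untested is meant among the compounds shown, and "the series" means these compounds.

Measured so far in a toxicity assay (Homo sapiens) for cytotoxicity, read by MTT assay, with a stated time of 48 h; on this read-out higher numbers stand for weaker inhibition and lower numbers for stronger inhibition:
compound 1 `O=C1C(O)=C(C(c2ccc(F)cc2)c2c[nH]c3ccccc23)C(=O)c2ccccc21` — 65200 nM
compound 2 `O=C1C(O)=C(C(c2ccccc2)c2c(-c3ccccc3)[nH]c3ccccc23)C(=O)c2ccccc21` — 26400 nM
compound 3 `Cc1[nH]c2ccccc2c1C(C1=C(O)C(=O)c2ccccc2C1=O)c1ccc(Cl)cc1` — 40300 nM

Among the three, compound 1 has the highest number in this assay; compound 3 lies within the scatter of it and cannot be separated from it, while compound 2 lies beyond the scatter with the lower number. No two of these compounds differ in one place only, so no single step can be read from the measured set.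

Compound 4 `O=C1C(O)=C(C(c2ccc([N+](=O)[O-])cc2)c2c[nH]c3ccccc23)C(=O)c2ccccc21` is the next compound, not yet measured. It is compound 1 with nitro in place of fluoro on an aromatic carbon, or read one bond further out, 4-fluorophenyl to 4-nitrophenyl. Everything else in compound 1 is kept.

Going by the values given here, no measured pair isolates a change of this kind, so nothing in the data fixes the direction. For compound 4 the expected step is a 1.3-fold lower number from compound 1 to compound 4 (0.12 log units; within the scatter), staying within the scatter, with a slight lean toward a lower number. Compound 4 is estimated at 50000 nM in this assay, within 20000 nM to 130000 nM.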

Compound 4, half-maximal inhibitory concentration: > 200000 nM
Compound 4 ended at the assay's limit; the forecaster's own chance of this, stated with the estimate: 20%; at least 4.0-fold (0.60 log units) between middle value and limit.
By their numbers in this assay, from the lowest: compounds 2, 3 and 1 (each within the scatter of the next, the first and the last beyond it). At a limit, above all of these: compound 4.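

In this assay, going by these compounds alone, nitro in place of fluoro on an aromatic carbon, para to a large group, gives the first step that can be read in one place: an at least 3.0-fold higher number from compound 1 to compound 4 (0.48 log units; beyond the scatter). Compound 4 stands at a limit of the assay, not at a number: the limit of > 200000 nM in this assay, at which 1 of the 4 values shown sits.

Within the data shown here, the earlier compounds held no pair differing in one place only, so this is the first sign that a change at this position alone can move the read-out beyond the scatter, with the direction given and the full size of the step unknown. Going by these compounds, whether an amine or a carboxylic acid at this position would move the number the same way stays open. Also open, on these data alone, is whether this change would step the same way on the backgrounds of compound 2 and compound 3.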